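The compounds below may be only part of what the source reports. "The series", "measured", "known", "first", "only" and "open" are said of these compounds alone.

Working notes on the carbonyl aryl group in the shared core, measured in a functional assay on A549 cells (Homo sapiens) for cytotoxicity, read by MTT assay, with a stated time of 48 h; a higher number here means a weaker inhibitor, a lower number a stronger inhibitor.

Compound 1 `COc1cc(-c2nnc3n2NC(c2ccco2)C(C(=O)c2cccs2)S3)cc(OC)c1OC` carries a thiophen-2-yl on the carbonyl carbon; in this assay compound 1 gives 78700 nM. Compound 2 `COc1cc(-c2nnc3n2NC(c2ccco2)C(C(=O)c2ccc(Cl)cc2)S3)cc(OC)c1OC` is the 4-chlorophenyl analogue, and in this assay compound 2 gives 51400 nM; the step of a 1.5-fold lower number from compound 1 to compound 2 (0.19 log units; within the scatter) does not separate the two compounds. Compound 3 `COc1ccc(C(=O)C2Sc3nnc(-c4cc(OC)c(OC)c(OC)c4)n3NC2c2ccco2)cc1` is the 4-methoxyphenyl analogue. In this assay compound 3 reaches only a limit, > 100000 nM, which is the floor noted as the limit of > 100000 nM in this assay, at which 1 of the 3 values shown sits. The steps of an at least 1.2-fold higher number from compound 1 to compound 3 (0.10 log units; that floor lies within the scatter) and an at least 1.9-fold higher number from compound 2 to compound 3 (0.28 log units; that floor lies within the scatter) are therefore floors only, and both floors lie within the scatter. Across the three aryl groups tried so far, the read-out has not moved beyond the scatter in either direction.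

Compound 4 `COc1cccc(C(=O)C2Sc3nnc(-c4cc(OC)c(OC)c(OC)c4)n3NC2c2ccco2)c1` is the next member: 3-methoxyphenyl in place of thiophen-2-yl on a carbonyl carbon. The step that bears on it most directly is an at least 1.2-fold higher number from compound 1 to compound 3 (0.10 log units; that floor lies within the scatter), the same exchange of thiophen-2-yl for a methoxyphenyl, with methoxy at a different ring position; that step did not leave the scatter. Going by the values given here, no measured step in this set shows a change beyond the scatter for an aryl swap on the carbonyl carbon, so the expected step of a 1.1-fold higher number from compound 1 to compound 4 (0.06 log units; within the scatter) is small and its direction uncertain, with a fair chance that only a limit is reported, as for compound 3. The estimate for compound 4 in this assay is 90000 nM, within a range of 40000 nM to 200000 nM.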

Compound 4, half-maximal inhibitory concentration: > 100000 nM
Compound 4: a limit, no number (the forecaster's own chance of this, stated with the estimate: 40%); middle value at least 1.1-fold (0.04 log units) away from the limit.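

Compound 4 also ends in a limit, not a number, in this assay, so moving from the 4-methoxyphenyl group to the 3-methoxyphenyl group on the carbonyl carbon gives a second compound at the same limit: the limit of > 100000 nM in this assay, at which 2 of the 4 values shown sit.

Against the two compounds with numbers, the result gives an at least 1.2-fold higher number from compound 1 to compound 4 (0.10 log units; that floor lies within the scatter) and an at least 1.9-fold higher number from compound 2 to compound 4 (0.28 log units; that floor lies within the scatter); both are floors only, so neither shows a real separation, and the true size of each step remains unknown. The step between the two methoxyphenyl compounds cannot be read, as both are limits, so these data do not show whether the place of the methoxy on the ring matters; what the result adds is that both methoxyphenyl compounds, unlike the thiophen-2-yl and 4-chlorophenyl compounds, give no number in this range.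

The compounds shown leave open whether any group on this carbonyl carbon can move the read-out beyond the scatter. A phenyl ring carrying an amine or a carboxylic acid, or a pyridine ring in place of the thiophen-2-yl, would test that question on the shared core.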